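Adding a cyano group to compound 3

A few compounds are considered here, and "the series" means these few. Any claim that something is new, unique, unknown or untested is made for them only; others in the source may bear on it.

Three compounds built on a shared core have numbers in a functional assay on QGY-7703 cells (Homo sapiens) for cytotoxicity, read by MTT assay, with a stated time of 24 h; on this read-out higher numbers stand for weaker inhibition and lower numbers for stronger inhibition. Compound 1 `O=C1/C(=C/c2ccncc2)CN(S(=O)(=O)c2ccccc2)C/C1=C\c1ccccc1F` gives 8400 nM, compound 2 `O=C1/C(=C/c2cccnc2)CN(S(=O)(=O)c2ccccc2)C/C1=C\c1ccccc1C(F)(F)F` gives 6240 nM, and compound 3 `O=C1/C(=C/c2ccncc2)CN(S(=O)(=O)c2ccccc2)C/C1=C\c1ccccc1C(F)(F)F` gives 6210 nM. Compound 3 therefore cannot be told apart from the other two on these numbers. Putting trifluoromethyl in place of fluoro gives a 1.4-fold lower number from compound 1 to compound 3 (0.13 log units; within the scatter), and putting pyridin-4-yl in place of pyridin-3-yl gives a 1.0-fold lower number from compound 2 to compound 3 (0.00 log units; within the scatter).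

Compound 4 `N#Cc1ccc(S(=O)(=O)N2C/C(=C\c3ccncc3)C(=O)/C(=C/c3ccccc3C(F)(F)F)C2)cc1` keeps all of compound 3 except that phenylsulfonyl becomes (4-cyanophenyl)sulfonyl, with cyano in place of hydrogen on an aromatic carbon. Neither measured step touches this group, and every tested compound carries the same unsubstituted phenylsulfonyl. The two steps are small, but they were made elsewhere in the molecule, so they offer only weak guidance here. With no measured evidence for a direction, no shift beyond the scatter is expected in this assay. The expected change is a 1.1-fold lower number from compound 3 to compound 4 (0.03 log units; within the scatter). For compound 4 the estimated value is 5800 nM, with an expected range from 2600 nM to 12000 nM.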

Compound 4, half-maximal inhibitory concentration: 6290 nM
Compound 4: the middle estimate sits 1.1-fold (0.04 log units) below what was measured; low and high end bracket the measured number.
By their numbers in this assay, from the lowest: compounds 3, 2, 4 and 1 (each within the scatter of the next).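

Until this point every compound carried the same unsubstituted phenylsulfonyl, so nothing showed how this part of the molecule responds to a substituent. In this assay the change to (4-cyanophenyl)sulfonyl gives a 1.0-fold higher number from compound 3 to compound 4 (0.01 log units; within the scatter) and so shows that a cyano group, with its 2 heavy atoms, can sit on this aromatic carbon, para to a large group, without a shift that stands out from the scatter. No measurement among the data shown offers an explanation for this flat result.

A single substituent at one place cannot show whether this part of the molecule is insensitive in general, and a different group here, such as an amine, a carboxylic acid or a longer chain, might still move the number. From the compounds shown here alone, it also stays open whether cyano would behave the same way on compounds carrying the other combinations seen so far, such as fluoro in place of trifluoromethyl or pyridin-3-yl in place of pyridin-4-yl.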